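The source may hold more compounds than are shown below. What is called first, only, known or untested is meant among the compounds shown, and "the series" means these compounds.

Measured so far:
compound 1, `O=S(=O)(NCCCNc1nccc(-c2c(-c3cccc(F)c3)nc3sccn23)n1)c1ccc(C(F)(F)F)cc1`, 11700 nM
compound 2, `O=C(NCCNc1nccc(-c2c(-c3cccc(F)c3)nc3sccn23)n1)c1ccccc1`, 17000 nM

Two compounds share the core and differ in the side chain on the chain nitrogen. In a functional assay on SK-MEL-28 cells (Homo sapiens) for cytotoxicity, read by MTT assay (a lower number here means a stronger inhibitor, a higher number a weaker inhibitor), compound 1 gives 11700 nM, and compound 2 gives 17000 nM; the gap between them is within the scatter, so neither can be set above the other. Compound 2 therefore stands at the higher of the two numbers without being distinguishable from compound 1. The next compound, compound 3, `O=S(=O)(NCCCNc1nccc(-c2c(-c3cccc(F)c3)nc3sccn23)n1)c1ccccc1`, carries the change (((phenylsulfonyl)amino)methyl in place of benzamido on a saturated chain carbon, two bonds along the chain from a nitrogen on an aromatic ring). It shares with compound 1 the three-carbon chain and the sulfonamide, but lacks the trifluoromethyl group on the phenyl. Within the data shown here, no measured pair isolates this change, so only a modest step is expected, if any, in this assay. For compound 3 the expected step is a 1.3-fold lower number from compound 2 to compound 3 (0.12 log units; within the scatter). Compound 3 is estimated at 13000 nM, within 5000 nM to 35000 nM.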

Compound 3, half-maximal inhibitory concentration: 6850 nM
Estimate against measurement, compound 3: 1.9-fold (0.28 log units) above; the measured number falls inside the stated range.
By their numbers in this assay, from the lowest: compounds 3, 1 and 2 (each within the scatter of the next, the first and the last beyond it).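

In this assay, among these compounds, ((phenylsulfonyl)amino)methyl in place of benzamido on a saturated chain carbon, two bonds along the chain from a nitrogen on an aromatic ring, gives a 2.5-fold lower number from compound 2 to compound 3 (0.39 log units; beyond the scatter), the first step in this set to stand clear of the scatter. Hydrogen in place of trifluoromethyl on an aromatic carbon gives a 1.7-fold lower number from compound 1 to compound 3 (0.23 log units; within the scatter), so these two groups cannot be told apart at this place in this assay. Nothing measured here speaks to what lies behind either step.

The step from compound 2 to compound 3 alters the linking group and the chain together, and the compounds shown do not separate the two. Also open, on these data alone, is how a longer chain, or an amine or a carboxylic acid in place of trifluoromethyl on the aromatic carbon, would read in this assay.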